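The source may report more compounds than this note shows. Statements on the series, on what has been measured and on what is new or still open speak of the compounds shown alone.

Measured compounds:
compound 1, `CN(C)CCCCCn1c2c(c3ccccc31)C(=O)c1c[n+]([O-])c3ccccc3c1C2=O`, with 560 nM in a functional assay on A-375 cells (Homo sapiens) for cytotoxicity, read by MTT assay, with a stated time of 72 h; on this read-out higher numbers stand for weaker inhibition and lower numbers for stronger inhibition;
compound 2, `O=C1c2c[n+]([O-])c3ccccc3c2C(=O)c2c1c1ccccc1n2Cc1cn(C[C@H](O)CO)nn1`, with 350 nM in this assay.

Going by the values given here, only two numbers are known, and compound 2 sits at one end of them: its sole neighbour is compound 1, separated by a 1.6-fold lower number from compound 1 to compound 2 (0.20 log units; within the scatter), a step that lies within the scatter, so the two compounds cannot be told apart on this read-out.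

Compound 3, `CC1(C)OC[C@H](Cn2cc(Cn3c4c(c5ccccc53)C(=O)c3c[n+]([O-])c5ccccc5c3C4=O)nn2)O1`, carries the change (2,2-dimethyl-1,3-dioxolan-4-yl in place of 1,2-dihydroxyethyl on a saturated chain carbon bound to an aromatic nitrogen). Among the compounds with values here, the one measured step, from compound 1 to compound 2, exchanged a different group at the same place and moved the number by no more than the scatter allows; it is the only step that bears on the new change, and it does not point in either direction. Nothing measured here separates a free diol from a ring-closed one at this position. The expectation is therefore a number close to that of compound 2, with a 1.2-fold higher number from compound 2 to compound 3 (0.08 log units; within the scatter) no larger than the scatter, in either direction. Compound 3 is estimated at 420 nM, with a range from 160 nM to 1100 nM.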

Compound 3, half-maximal inhibitory concentration: 180 nM
Compound 3: the middle estimate sits 2.3-fold (0.37 log units) above what was measured; the range from low to high includes it.
By their numbers in this assay, from the lowest: compounds 3, 2 and 1 (each within the scatter of the next, the first and the last beyond it).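

In this assay the 2,3-dihydroxypropyl group of compound 2 gives way to the (2,2-dimethyl-1,3-dioxolan-4-yl)methyl group of compound 3, with a 1.9-fold lower number from compound 2 to compound 3 (0.29 log units; within the scatter) and so no separation of the two on this read-out. The place on a saturated chain carbon bound to an aromatic nitrogen therefore takes a group with 0 hydrogen-bond donors and a five-membered non-aromatic ring as well as one with 2 hydrogen-bond donors and no ring, without a step beyond the scatter; for this one pair, the free diol is not needed to keep the number where it stands. Nothing at hand tells what either group does in the cells or accounts for the size of the step.

The compounds shown leave open whether a single hydroxyl, a methoxy group or a carboxylic acid in place of the diol would give a number that stands clear of these. They also leave open how the opposite configuration at the defined stereocentre would read, and what a longer chain at this place would do.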